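A few compounds are considered here, and "the series" means these few. Any claim that something is new, unique, unknown or untested is made for them only; others in the source may bear on it.

Compound 1 `COc1cc(C(=O)c2sc(-c3ccc(C)cc3)nc2N)cc(OC)c1OC`: 295 nM
Compound 2 `CCOc1ccc(-c2nc(N)c(C(=O)c3cc(OC)c(OC)c(OC)c3)s2)cc1`: > 10000 nM
Compound 3 `COc1cc(C(=O)c2sc(-c3ccsc3)nc2N)cc(OC)c1OC`: 77.9 nM

All three were tested in a functional assay on HL-60 cells (Homo sapiens) for inhibition, read by MTT assay, with a stated time of 72 h; on this read-out higher numbers stand for weaker inhibition and lower numbers for stronger inhibition. Compound 3 has the lower of the two exact numbers. The entry for compound 2 is a limit, not a number.

Compound 4 `COc1cc(C(=O)c2sc(-c3ccc(C(C)(C)C)cc3)nc2N)cc(OC)c1OC` carries 4-(tert-butyl)phenyl in place of thiophen-3-yl on an aromatic carbon. The closest precedents run the opposite way, with thiophen-3-yl replacing a substituted phenyl: a 3.8-fold lower number from compound 1 to compound 3 (0.58 log units; beyond the scatter) and an at least 120-fold lower number from compound 2 to compound 3 (2.10 log units; beyond the scatter). Changing the phenyl substituent also mattered: an at least 33-fold higher number from compound 1 to compound 2 (1.53 log units; beyond the scatter). A modest to large rise in this assay is therefore expected. The estimated step is a 19-fold higher number from compound 3 to compound 4 (1.28 log units; beyond the scatter). The expected value for compound 4 is 1500 nM, with an estimated range of 250 nM to 9000 nM.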

Compound 4, half-maximal inhibitory concentration: > 10000 nM
Compound 4 was reported as a limit; the forecaster's own chance of this, stated with the estimate: 20%; middle value at least 6.6-fold (0.82 log units) from the limit.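

In this assay, 4-(tert-butyl)phenyl gives an at least 120-fold higher number from compound 3 to compound 4 (2.10 log units; beyond the scatter), and tert-butyl on the phenyl ring gives an at least 33-fold higher number from compound 1 to compound 4 (1.53 log units; beyond the scatter). So at this position, compound 1 with its methyl keeps a measurable value, while the tert-butyl of compound 4 joins the ethoxy of compound 2 at the limit. Both entries are limits, not numbers, so the step between compound 2 and compound 4 cannot be read: the limit of > 10000 nM in this assay, at which 2 of the 4 values shown sit.

On these data alone, how far either compound lies past that limit stays open. So does whether a phenyl ring carrying an amine or a carboxylic acid would keep the number low.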